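Dropping the Chlorine from Compound 1: What to Expect

The source may hold more compounds than are shown below. What is called first, only, known or untested is meant among the compounds shown, and "the series" means these compounds.

Of the compounds shown here, two have been measured in a functional assay on HCT-116 cells (Homo sapiens) for inhibition, read by MTT assay, with a stated time of 24 h, tested at 2.5 uM; on this read-out higher numbers stand for more inhibition of growth at the one concentration tested and lower numbers for less inhibition of growth. Compound 1, `CS(=O)(=O)c1ccc(-c2cnc3[nH]cc(-c4nnc(-c5ccc(Cl)cc5)o4)c(=O)c3c2)cc1`, gives 2.06% in this assay, the smaller of the two numbers on its face, though only by a gap that lies within the scatter. Compound 2, `O=c1c(-c2nnc(-c3ccc(F)cc3)o2)c[nH]c2ncc(-c3ccncc3)cc12`, gives 7.54% in this assay, so the two compounds read as equally weak at the single concentration tested, both close to no inhibition of growth.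

Compound 3, `CS(=O)(=O)c1ccc(-c2cnc3[nH]cc(-c4nnc(-c5ccccc5)o4)c(=O)c3c2)cc1`, has not yet been measured. It differs from compound 1 in one place: hydrogen in place of chloro on an aromatic carbon. Within the data shown here, no pair of measured compounds shows this kind of change, so the series gives no direct guide to its size.

Because compound 1 gives 2.06%, a value close to no inhibition of growth, compound 3 is expected to stay in the same low region. The step of a number 1.9 percentage points higher from compound 1 to compound 3 (within the scatter) is expected to be none beyond the scatter. Compound 3 is estimated at 4%, with a range from -8% to 16%.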

Compound 3, percent growth inhibition at one concentration: 0.53%
Estimate against measurement, compound 3: 3.5 percentage points above; the range from low to high includes it.
By their numbers in this assay, from the lowest: compounds 3, 1 and 2 (each within the scatter of the next).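

In this assay, among these compounds, the change from 4-chlorophenyl to phenyl gives a number 1.5 percentage points lower from compound 1 to compound 3 (within the scatter), the first direct reading of this change. Hydrogen in place of chloro on this aromatic carbon, para to a large group, therefore leaves the read-out unmoved, and compound 1 and compound 3 both stay close to no inhibition of growth at the single concentration tested, so the chloro group is not what separates these two readings from any measurable inhibition, and taking it away uncovers none. No measurement among the data shown bears on why the step is this small.

With both readings lying so near no inhibition, this one step cannot tell whether the position is indifferent to change in general or only to this particular pair of substituents. The compounds shown leave open whether an amine, a carboxylic acid or a methoxy group at this same place on the phenyl ring would lift the reading beyond the scatter, or would leave it just as low.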